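Replacing the Nitrophenyl Group: A Higher Number Expected

This account rests on a few compounds, and the source may have more. Where it says the series, first, only, none or still open, it means among the compounds named here.

In a functional assay on HeLa cells (Homo sapiens) for cytotoxicity, read by MTT assay, with a stated time of 48 h (on this read-out higher numbers stand for weaker inhibition and lower numbers for stronger inhibition), three compounds sharing one core have been measured. Compound 2 `Cc1ccc(S(=O)(=O)/N=C(/CCNC2=CC(=O)c3ccccc3C2=O)Nc2ccccc2[N+](=O)[O-])cc1` gives 3310 nM, the lowest number of the three. Compound 1 `Cc1ccc(S(=O)(=O)/N=C(/CCNC2=CC(=O)c3ccccc3C2=O)Nc2ccc(Cl)cc2)cc1` gives 13400 nM, and compound 3 `Cc1ccc(S(=O)(=O)/N=C(/CCNC2=CC(=O)c3ccccc3C2=O)Nc2cccc(C(F)(F)F)c2)cc1` gives 77600 nM. The step of a 4.0-fold lower number from compound 1 to compound 2 (0.61 log units; beyond the scatter) shows the 2-nitrophenyl group giving the lowest number of the aryl groups tried, and the step of a 23-fold higher number from compound 2 to compound 3 (1.37 log units; beyond the scatter) shows how much is lost when it is exchanged for 3-(trifluoromethyl)phenyl. Compound 4 `COc1ccc(N/C(CCNC2=CC(=O)c3ccccc3C2=O)=N\S(=O)(=O)c2ccc(C)cc2)cc1OC` is not yet measured; it differs from compound 2 by 3,4-dimethoxyphenyl in place of 2-nitrophenyl on an amine nitrogen. For the measured compounds named here, no measured compound carries a dimethoxyphenyl group, so the only guide is that both departures from the 2-nitrophenyl group seen so far, read through a 4.0-fold lower number from compound 1 to compound 2 (0.61 log units; beyond the scatter) in reverse and through a 23-fold higher number from compound 2 to compound 3 (1.37 log units; beyond the scatter), gave higher numbers in this assay. A higher number is therefore expected for compound 4 as well, more likely a modest step than a large one, with wide uncertainty. The expected step is a 4.5-fold higher number from compound 2 to compound 4 (0.66 log units; beyond the scatter). Compound 4 is estimated at 15000 nM, within a range from 4000 nM to 60000 nM.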

Compound 4, half-maximal inhibitory concentration: 14500 nM
Compound 4: middle estimate off by 1.0-fold (0.01 log units), on the high side; the measured number falls inside the stated range.
By their numbers in this assay, from the lowest: compound 2; then compounds 1 and 4 (each within the scatter of the next); then compound 3.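

In this assay, the 3,4-dimethoxyphenyl group adds a third replacement for 2-nitrophenyl on this amine nitrogen that gives a higher number, with a 4.4-fold higher number from compound 2 to compound 4 (0.64 log units; beyond the scatter), so compound 2 keeps the lowest number across three quite different aryl groups. The 4-chlorophenyl and 3,4-dimethoxyphenyl groups cannot be told apart here, with a 1.1-fold higher number from compound 1 to compound 4 (0.03 log units; within the scatter), while a 5.4-fold lower number from compound 3 to compound 4 (0.73 log units; beyond the scatter) leaves compound 3 with the highest number of the four. No measurement shown explains why these aryl groups rank as they do.

For the compounds shown here, only one nitro-bearing ring appears, so it remains open whether the low number of compound 2 belongs to the nitro group itself, or whether an amine or a carboxylic acid on that phenyl ring would serve equally well. Going by these compounds, all four compounds share the rest of the core, so the effect of changing it also remains open.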